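Methyl position on the benzamide of a trichlorophenyl thiazolylidene series

The source may report more compounds than this note shows. Statements on the series, on what has been measured and on what is new or still open speak of the compounds shown alone.

Measured so far:
compound 1 `Cc1ccccc1C(=O)/N=c1\scc(C)n1-c1cc(Cl)c(Cl)cc1Cl`, 150 nM
compound 2 `Cc1cs/c(=N\C(=O)c2cccc3ccccc23)n1-c1cc(Cl)c(Cl)cc1Cl`, 150 nM

In an assay on isolated protein for inhibition of Alpha glucosidase (Homo sapiens), with stated times of 5 min and 30 min (a lower number here means a stronger inhibitor, a higher number a weaker inhibitor), compound 1 gives 150 nM. Compound 2 gives 150 nM in this assay, and the two values lie together within the scatter, so compound 1 stands level with its nearest neighbour. Compound 3 `Cc1cccc(C(=O)/N=c2\scc(C)n2-c2cc(Cl)c(Cl)cc2Cl)c1` is not yet measured; it differs from compound 1 by 3-methylphenyl in place of 2-methylphenyl on a carbonyl carbon. Among the measured compounds shown here, no step between measured compounds covers a move of this kind, so no direction is indicated; a step from compound 1 to compound 3 no larger than the scatter is expected, a 1.3-fold higher number from compound 1 to compound 3 (0.12 log units; within the scatter). Compound 3 is estimated at 200 nM, range 60 nM to 700 nM.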

Compound 3, half-maximal inhibitory concentration: 100 nM
Compound 3: the middle estimate sits 2.0-fold (0.30 log units) above what was measured; the range from low to high includes it.
By their numbers in this assay, from the lowest: compounds 3, 1 and 2 (each within the scatter of the next).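

With 3-methylphenyl in place of 2-methylphenyl on a carbonyl carbon, this assay shows a 1.5-fold lower number from compound 1 to compound 3 (0.18 log units; within the scatter), so the two methylphenyl isomers cannot be told apart here. Among the compounds shown here, this is the first matched change at this place, and it shows that moving the methyl between these two printed positions leaves the number within the scatter. No supporting measurement bears on this result.

Still open, going by these compounds, is whether a carboxylic acid, an amine or a longer chain in place of the methyl would keep the number level. Also open, on these data alone, is whether any change at this place gives a step beyond the scatter.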